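Hydroxy in Place of Nonyl: Expectation for Compound 3

The compounds below may be only part of what the source reports. "The series", "measured", "known", "first", "only" and "open" are said of these compounds alone.

Compound 1 `CC1(C)CC(=O)C=C(Nc2ccc(Cl)cc2)C1` gives 15 ug/mL.
Compound 2 `CCCCCCCCCCCSC(=S)C1=C(Nc2ccc(Cl)cc2)CC(C)(C)CC1=O` gives > 50 ug/mL.

In a functional assay on PBMC cells (Homo sapiens) for inhibition, read by thymidine incorporation, with a stated time of 72 h (a higher number here means a weaker inhibitor, a lower number a stronger inhibitor), compound 1 gives 15 ug/mL. Compound 2 sits at the limit of > 50 ug/mL in this assay, at which 1 of the 2 values shown sits, so its reading > 50 ug/mL is a limit of the assay and not a number. Compound 3 `CC1(C)CC(=O)C(C(=S)SCCO)=C(Nc2ccc(Cl)cc2)C1` differs from compound 2 by hydroxy in place of nonyl on a saturated chain carbon, two bonds along the chain from a sulfur. Going by the values given here, no pair of measured compounds differs in one place, so no measured step tells how large a change of this kind is in this assay. Because compound 2 is known only through > 50 ug/mL, the step to compound 3 can only be judged against that limit. Compound 3 is expected to give about 30 ug/mL in this assay, with a range from 10 ug/mL to 50 ug/mL. The expected step of an at least 1.6-fold lower number from compound 2 to compound 3 (0.22 log units; that floor lies within the scatter) is toward a stronger inhibitor, though there is a real chance that compound 3 too is reported only as a limit.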

Compound 3, half-maximal inhibitory concentration: 21 ug/mL
The estimate for compound 3 lay 1.4-fold (0.15 log units) above the measured number; the measured number falls inside the stated range.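

In this assay compound 2 reads > 50 ug/mL, which is a limit of the assay and not a number. Hydroxy in place of nonyl, on a saturated chain carbon, two bonds along the chain from a sulfur, gives an at least 2.3-fold lower number from compound 2 to compound 3 (0.37 log units; beyond the scatter), so what stands at this place does change the reading in this assay. Set against the hydrogen atom on the double-bonded ring carbon of compound 1, the whole group of 6 heavy atoms ending in hydroxy gives a 1.4-fold higher number from compound 1 to compound 3 (0.15 log units; within the scatter), so with this ending the group leaves a reading that the scatter cannot separate from that of the parent.

From the compounds shown here alone, the true size of the step from nonyl to hydroxy stays open, as only its floor can be read. Also open, going by these compounds, is how a butyl chain, an amine or a carboxylic acid would read at this same place.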